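This account rests on a few compounds, and the source may have more. Where it says the series, first, only, none or still open, it means among the compounds named here.

In a functional assay on K562 cells (Homo sapiens) for cytotoxicity, read by CellTiter-Blue, with a stated time of 72 h (a lower number here means a stronger inhibitor, a higher number a weaker inhibitor), compound 1 `C/C=C(\C)[C@H]1OC(=O)[C@@H](C)NC(=O)[C@H]([C@@H](C)CC)NC(=O)CN(C)C(=O)[C@@H](Cc2ccccc2)N(C)C(=O)[C@H](C)NC(=O)[C@@H](CC(C)C)OC(=O)/C(C)=C/C[C@H](OCSC)[C@@H]1C` gives 0.0063 nM, the lowest number of the three measured, far under compound 2 `C/C=C(\C)[C@@H](O)[C@@H](C)[C@@H]1C/C=C(\C)C(=O)O[C@H](CC(C)C)C(=O)N[C@H](C)C(=O)N(C)[C@H](Cc2ccccc2)C(=O)N(C)CC(=O)N[C@@H]([C@@H](C)CC)C(=O)N[C@H](C)C(=O)O1` at 925 nM and compound 3 `C/C=C(\C)[C@H]1OC(=O)[C@@H](C)NC(=O)[C@H]([C@@H](C)CC)NC(=O)CN(C)C(=O)[C@@H](Cc2ccccc2)N(C)C(=O)[C@@H](C)NC(=O)[C@@H](CC(C)C)OC(=O)/C(C)=C/C[C@H](OCSC)[C@@H]1C` at 1190 nM. Within the data shown here, the only measured step, a 190000-fold higher number from compound 1 to compound 3 (5.28 log units; beyond the scatter), is large, due to the fact that compounds 1 and 3 differ only in the configuration as drawn. That change lies at a saturated ring carbon, so it shows how sensitive this number can be but offers no direct guide to the next change. Compound 4 `C/C=C(\C)[C@H]1OC(=O)[C@@H](C)NC(=O)[C@H]([C@@H](C)CC)NC(=O)CN(C)C(=O)[C@@H](Cc2ccc(Cl)cc2)N(C)C(=O)[C@H](C)NC(=O)[C@@H](CC(C)C)OC(=O)/C(C)=C/C[C@H](OCSC)[C@@H]1C` carries chloro in place of hydrogen on an aromatic carbon, turning benzyl into 4-chlorobenzyl. Among the measured compounds shown here, no measured step covers such a swap, so only a moderate move towards a higher number is expected in this assay. The expected size is a 2.4-fold higher number from compound 1 to compound 4 (0.38 log units; beyond the scatter). The estimate for compound 4 is 0.015 nM, with an expected range from 0.002 nM to 0.15 nM.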

Compound 4, half-maximal inhibitory concentration: 7.1 nM
For compound 4 the middle estimate is 470-fold (2.68 log units) below the measured one; the whole stated range lies below it.
By their numbers in this assay, from the lowest: compound 1; then compound 4; then compounds 2 and 3 (each within the scatter of the next).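

Turning benzyl into 4-chlorobenzyl brings a 1100-fold higher number from compound 1 to compound 4 (3.05 log units; beyond the scatter). Until now, only a change of configuration had shown so large a step, and here a single chlorine atom on an aromatic carbon does the same with the configuration as drawn left untouched. Nothing in the available evidence explains why this one atom matters so much.

Open, on these data alone, is whether the number depends on chlorine itself or on any group other than hydrogen at this carbon. Fluoro, methyl or methoxy in the same place would test that, and so would chloro on another carbon of the same ring.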